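Ring-Nitrogen Substituent and Potency at the Glutamate Receptor

The source may report more compounds than this note shows. Statements on the series, on what has been measured and on what is new or still open speak of the compounds shown alone.

Compound 1, `CCN1CCc2nc(C#Cc3ccccc3)sc2C1`: in an assay on HEK293 cells for positive allosteric modulation of metabotropic glutamate receptor 5 (Homo sapiens), read by FLIPR, with a stated time of 1 h (a higher number here means that more compound is needed for the effect, a lower number that less compound is needed), compound 1 gives only a limit, > 10000 nM.
Compound 2, `CCCCN1CCc2nc(C#Cc3ccccc3)sc2C1`: in this assay compound 2 gives 110 nM.
Compound 3, `CC1CC1C(=O)N1CCc2nc(C#Cc3ccccc3)sc2C1`: in this assay compound 3 gives 9.4 nM.

Compound 3 has the lowest of the two numbers measured; its nearest neighbour is compound 2, which sits a 12-fold lower number from compound 2 to compound 3 (1.07 log units; beyond the scatter). Compound 1 sits at the limit of > 10000 nM in this assay, at which 1 of the 3 values shown sits, so its value is a limit and not a number, and its step to compound 3 is an at least 1000-fold lower number from compound 1 to compound 3 (3.02 log units; beyond the scatter).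

Compound 4, `O=C(C1CC12CCC2)N1CCc2nc(C#Cc3ccccc3)sc2C1`, differs from compound 3 by a group of 6 heavy atoms (6 carbon; one three-membered non-aromatic ring of carbon only, one four-membered non-aromatic ring of carbon only) in place of a group of 4 heavy atoms (4 carbon; one three-membered non-aromatic ring of carbon only), on a carbonyl carbon. The measured steps all concern what hangs from the ring nitrogen: an alkyl group against a carbonyl-bearing group, with large steps a 12-fold lower number from compound 2 to compound 3 (1.07 log units; beyond the scatter) and an at least 1000-fold lower number from compound 1 to compound 3 (3.02 log units; beyond the scatter). Within the data shown here, no measured step alters the group on the carbonyl carbon itself, which is where compound 4 changes. The carbonyl on the ring nitrogen and the small carbon ring are kept, so the step is expected to stay within the scatter, a 1.1-fold higher number from compound 3 to compound 4 (0.03 log units; within the scatter). Compound 4 is therefore estimated at 10 nM in this assay, within a range from 3 nM to 35 nM.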

Compound 4, half-maximal effective concentration: 3.9 nM
Beside the measured number, compound 4's estimate is 2.6-fold (0.41 log units) above it; low and high end bracket the measured number.
By their numbers in this assay, from the lowest: compound 4; then compound 3; then compound 2. At a limit, above all of these: compound 1.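

Every earlier step changed what hangs from the ring nitrogen, whereas in this assay the step (a 2.4-fold lower number from compound 3 to compound 4 (0.38 log units; beyond the scatter)) shows that the group on the carbonyl carbon also matters: replacing 2-methylcyclopropyl with a group holding a three-membered and a four-membered carbon ring gives a modest change, though one beyond the scatter. The larger carbon group is therefore accepted at this position, and it widens the distance from the butyl group on the ring nitrogen of compound 2, with the step now a 28-fold lower number from compound 2 to compound 4 (1.45 log units; beyond the scatter). Compound 1 gives a limit and not a number, so the step (an at least 2500-fold lower number from compound 1 to compound 4 (3.40 log units; beyond the scatter)) holds only as a bound: the limit of > 10000 nM in this assay, at which 1 of the 4 values shown sits.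

With a single change at this position, the compounds shown cannot separate the effect of the four-membered ring from that of the added carbon atoms; a cyclobutyl or a tert-butyl group on the carbonyl carbon would help to tell them apart. Also open, as far as these compounds go, is how this position responds to groups carrying other atoms, such as an amine or an ether oxygen, instead of carbon alone.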